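Replacing the Chlorophenyl Ester Group: Estimating Compound 4

The source may report more compounds than this note shows. Statements on the series, on what has been measured and on what is new or still open speak of the compounds shown alone.

Compound 1 `COc1ccc(C2CC(=NOC(=O)c3cccc(Cl)c3)CC(c3ccc(OC)cc3)N2C)cc1` gives 136000 nM
Compound 2 `COc1ccc(C2CC(=NOC(=O)c3cc(O)cc(O)c3)CC(c3ccc(OC)cc3)N2C)cc1` gives 19000 nM
Compound 3 `COc1ccc(C2CC(=NOC(=O)c3cc(O)c(O)c(O)c3)CC(c3ccc(OC)cc3)N2C)cc1` gives 18000 nM

These three share one core and differ only in the aryl group on the carbonyl carbon of the ester. In a functional assay, with a stated time of 30 min (a lower number here means a stronger inhibitor, a higher number a weaker inhibitor), compound 1 gives the highest number of the three, so it is the weakest inhibitor shown. Moving to compound 2 brings a 7.2-fold lower number from compound 1 to compound 2 (0.85 log units; beyond the scatter) and moving to compound 3 brings a 7.6-fold lower number from compound 1 to compound 3 (0.88 log units; beyond the scatter), while a 1.1-fold lower number from compound 2 to compound 3 (0.02 log units; within the scatter). Compound 4 `COc1ccc(C(=O)ON=C2CC(c3ccc(OC)cc3)N(C)C(c3ccc(OC)cc3)C2)cc1` differs from compound 1 as follows: 4-methoxyphenyl in place of 3-chlorophenyl on a carbonyl carbon. Going by the values given here, no measured step covers this exact change; the two measured steps show a modest gain when hydroxy-bearing rings replace 3-chlorophenyl, but 4-methoxyphenyl has no hydroxy group. A smaller gain, or none beyond the scatter, is therefore expected, a 2.3-fold lower number from compound 1 to compound 4 (0.36 log units; beyond the scatter). Compound 4 is estimated at 60000 nM, within 15000 nM to 200000 nM.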

Compound 4, half-maximal inhibitory concentration: 68000 nM
For compound 4 the middle estimate is 1.1-fold (0.05 log units) below the measured one; the range from low to high includes it.
By their numbers in this assay, from the lowest: compounds 3 and 2 (each within the scatter of the next); then compounds 4 and 1 (each within the scatter of the next).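

In this assay, 4-methoxyphenyl in place of 3-chlorophenyl on this carbonyl carbon gives a 2.0-fold lower number from compound 1 to compound 4 (0.30 log units; within the scatter), so these two rings, neither bearing a hydroxy group, cannot be told apart here. The hydroxy-bearing rings remain the stronger inhibitors, with a 3.8-fold higher number from compound 3 to compound 4 (0.58 log units; beyond the scatter) and a 3.6-fold higher number from compound 2 to compound 4 (0.55 log units; beyond the scatter), so the earlier gap now holds against a second ring without hydroxy groups. No supporting data are available to explain this difference. The compounds shown leave open whether a single hydroxy group on the ring would give the same result, and how a ring bearing an amine or a carboxylic acid would compare.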